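Swapping methylsulfanyl for piperidin-1-yl in compound 2

The compounds below may be only part of what the source reports. "The series", "measured", "known", "first", "only" and "open" are said of these compounds alone.

Measured so far in a functional assay on MCF7 cells (Homo sapiens) for cytotoxicity, read by MTT assay, with a stated time of 72 h (a lower number here means a stronger inhibitor, a higher number a weaker inhibitor), for the two compounds:
Compound 1 `CSc1nc(Cl)c(C(=O)c2ccccc2)s1` gives 91000 nM
Compound 2 `CSc1nc(Br)c(C(=O)c2ccccc2)s1` gives 67000 nM

Among the measured compounds shown here, compound 2 gives 67000 nM and stands level with compound 1, the only other compound measured. For the measured compounds named here, the one measured step is a 1.4-fold lower number from compound 1 to compound 2 (0.13 log units; within the scatter) for bromo in place of chloro on an aromatic carbon. The two compounds therefore cannot be told apart on these numbers.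

Going by the values given here, compound 3 `O=C(c1ccccc1)c1sc(N2CCCCC2)nc1Br` keeps the rest of compound 2 but carries piperidin-1-yl in place of methylsulfanyl on an aromatic carbon as its single change. Among the compounds with values here, this change is larger than a swap of one halogen for another, and no measured compound carries the piperidin-1-yl group. The step of a 1.4-fold lower number from compound 1 to compound 2 (0.13 log units; within the scatter) concerns another place on the core, so it offers only weak guidance, and the data give no firm direction. In this assay the expected result is therefore a 1.2-fold lower number from compound 2 to compound 3 (0.09 log units; within the scatter) as an estimate with wide uncertainty. Compound 3 is estimated at 55000 nM with an expected range from 18000 nM to 170000 nM in this estimate.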

Compound 3, half-maximal inhibitory concentration: 35000 nM
Compound 3: middle estimate off by 1.6-fold (0.20 log units), on the high side; the range from low to high includes it.
By their numbers in this assay, from the lowest: compounds 3, 2 and 1 (each within the scatter of the next, the first and the last beyond it).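

The place on the shared core next to the ring nitrogen and next to the ring sulfur had not been varied in the earlier pair, where only the bromo and chloro groups differed. In this assay, exchanging methylsulfanyl, with its 2 heavy atoms and no ring, for piperidin-1-yl, with 6 heavy atoms in a six-membered non-aromatic ring, gives a 1.9-fold lower number from compound 2 to compound 3 (0.28 log units; within the scatter) and so does not separate the two compounds, which shows that this much bigger group can sit at this place without a shift beyond the usual variation between repeats. No accompanying measurement offers an explanation for this result.

A single exchange cannot show whether other groups at this place, such as morpholin-4-yl, dimethylamino or a longer alkyl chain ending in an amine, would give a number clearly apart from those of compound 2 and compound 3. Also open, going by these compounds, is whether a hydroxy or methoxy group on the group of 8 heavy atoms would matter more than either change seen so far.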